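Trimming the Side Chain of Compound 3 to Compound 4

The source may hold more compounds than are shown below. What is called first, only, known or untested is meant among the compounds shown, and "the series" means these compounds.

Of the compounds shown here, three sharing one core have been measured in a functional assay on the whole organism (Tail, strain ICR) with Mus musculus as the target, in the tail flick test, with a stated time of 150 min, at a dose of 25 umol/kg by the oral route; a lower number here means a weaker effect, a higher number a stronger effect of the compound at the dose given. Compound 1, `N=C(N)NCCC[C@H](NC(=O)CN(c1nc(Cl)nc2[nH]cnc12)C1CC1)C(=O)O`, gives 7.19%. Compound 2, `NC(=O)C[C@H](NC(=O)CN(c1nc(Cl)nc2[nH]cnc12)C1CC1)C(=O)O`, gives 7.51%. Compound 3, `NCCCC[C@H](NC(=O)CN(c1nc(Cl)nc2[nH]cnc12)C1CC1)C(=O)O`, gives 11.6%, which stands highest of the three numbers, although its separation from both others lies within the scatter: a number 4.1 percentage points higher from compound 2 to compound 3 (within the scatter) and a number 4.4 percentage points higher from compound 1 to compound 3 (within the scatter). The remaining pair is likewise close, a number 0.3 percentage points higher from compound 1 to compound 2 (within the scatter).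

Compound 4, `C[C@H](NC(=O)CN(c1nc(Cl)nc2[nH]cnc12)C1CC1)C(=O)O`, differs from compound 3 in a single place: hydrogen in place of 3-aminopropyl on a saturated chain carbon, two bonds along the chain from an amide-type nitrogen and a carbonyl carbon. The step from compound 2 to compound 3 bears most directly on this, since it too exchanged the group on the same saturated chain carbon, and it stayed within the scatter; the step from compound 1 to compound 3, an exchange four bonds along the chain, stayed within the scatter as well. Every exchange of the side chain seen so far has thus left this assay's readout within the scatter of the others. The expected step is therefore none beyond the scatter, a number 2.6 percentage points lower from compound 3 to compound 4 (within the scatter). Compound 4 is expected to give 9%, with a range from 2% to 18%.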

Compound 4, a percentage reported as activity, at one dose (the size of the read-out at that dose, not a potency): 14.7%
Estimate against measurement, compound 4: 5.7 percentage points below; the measured number falls inside the stated range.
By their numbers in this assay, from the lowest: compounds 1, 2, 3 and 4 (each within the scatter of the next).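

With compound 4, the side chain at this saturated chain carbon is gone altogether, and the read-out in this assay still does not separate from that of any earlier compound: a number 3.1 percentage points higher from compound 3 to compound 4 (within the scatter), a number 7.2 percentage points higher from compound 2 to compound 4 (within the scatter) and a number 7.5 percentage points higher from compound 1 to compound 4 (within the scatter). The earlier compounds shown here all carried a nitrogen-bearing side chain at this carbon, so they could only compare one such chain with another; compound 4 adds that neither 3-aminopropyl, carbamoyl nor the larger group of compound 1 is required for a read-out of this size, and that hydrogen in their place is tolerated at the dose given. No measurement is available here that would explain these numbers.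

Since all four compounds lie within the scatter of their neighbours, the compounds shown do not settle whether any group at this carbon truly moves the read-out, and a single dose and time point gives no potency. Also open, going by these compounds, is whether a side chain of another kind, such as a carboxylic acid, a hydroxymethyl group, an isopropyl group or a phenyl ring, would step beyond the scatter.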